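The source may report more compounds than this note shows. Statements on the series, on what has been measured and on what is new or still open speak of the compounds shown alone.

Compound 1 `COc1cc(/C=C/C(=O)c2cccc(-n3cc(-c4ccc(Cl)cc4)[nH]c3=O)c2)cc(OC)c1OC`: 1740 nM
Compound 2 `COc1cc(/C=C/C(=O)c2cccc(-n3cc(-c4ccccc4)[nH]c3=O)c2)ccc1O`: 1550 nM
Compound 3 `O=C(/C=C/c1cccc(O)c1)c1cccc(-n2cc(-c3ccc(Cl)cc3)[nH]c2=O)c1`: 1270 nM

All three were tested in a functional assay on MCF7 cells (Homo sapiens) for inhibition; on this read-out lower numbers stand for stronger inhibition of growth and higher numbers for weaker inhibition of growth. Compound 1 gives the highest of the three numbers, yet its gaps to compound 2, which gives 1550 nM, and to compound 3, which gives 1270 nM, both lie within the usual scatter, so the three cannot be put in an order. Compound 4 `COc1ccc(-c2cn(-c3cccc(C(=O)/C=C/c4cc(OC)c(OC)c(OC)c4)c3)c(=O)[nH]2)cc1` differs from compound 1 in a single place: methoxy in place of chloro on an aromatic carbon. Among the compounds with values here, no measured pair shows this exchange, so there is no step to lean on. The expectation is that the exchange shifts growth inhibition little, if at all, beyond the scatter. The estimated step of a 1.2-fold lower number from compound 1 to compound 4 (0.06 log units; within the scatter) is expected to be small. Compound 4 is expected to give 1500 nM, with a range from 600 nM to 3800 nM.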

Compound 4, concentration for 50% growth inhibition: 440 nM
Estimate against measurement, compound 4: 3.4-fold (0.53 log units) above, and the stated range ends above it.
By their numbers in this assay, from the lowest: compound 4; then compounds 3, 2 and 1 (each within the scatter of the next).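

In this assay, within the data shown here, the change from 4-chlorophenyl to 4-methoxyphenyl brings a 4.0-fold lower number from compound 1 to compound 4 (0.60 log units; beyond the scatter) and so shows that growth inhibition responds to what sits on this ring carbon, which the earlier compounds could not show. Nothing at hand explains why the methoxy compound gives the lower number. Open, as far as these compounds go, is how other groups at this place, such as an amine or the longer ethoxy chain, would compare with methoxy. Also open, from the compounds shown here alone, is whether the same exchange would give a similar step with different groups elsewhere on the molecule.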